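Shortening the Alkyl Chain on a Thiourea Nitrogen

The source may hold more compounds than are shown below. What is called first, only, known or untested is meant among the compounds shown, and "the series" means these compounds.

Measured so far:
- compound 1, `S=C(Nc1ccccc1)Nc1ccccn1`: >= 200000 nM
- compound 2, `CCCCNC(=S)NCc1ccccc1`: 177000 nM

Two thioureas have been tested in a toxicity assay on RAW264.7 cells (Mus musculus) for cytotoxicity, read by MTT assay, with a stated time of 24 h; a lower number here means that less compound is tolerated, a higher number that more compound is tolerated. Compound 1 reaches only a limit of the assay there, giving >= 200000 nM, so no number is known for it. Compound 2 gives 177000 nM in this assay. Within the data shown here, compound 2 therefore holds the only true number in the set, with the other result sitting at the limit of >= 200000 nM in this assay, at which 1 of the 2 values shown sits.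

Compound 3, `CC(C)NC(=S)NCc1ccccc1`, has not yet been tested. It differs from compound 2 in one place: isopropyl in place of butyl on an amide-type nitrogen. Isopropyl in place of butyl on an amide-type nitrogen is a small trim of the chain, and nothing measured here links such a trim to a change in how much compound the cells tolerate.

Among the measured compounds shown here, since no measured step exists to lean on, the expectation is that the change from compound 2 to compound 3 stays within the scatter of this assay, with a 1.1-fold higher number from compound 2 to compound 3 (0.05 log units; within the scatter) as the expected step. Compound 3 is estimated at 200000 nM in this assay, with a range from 100000 nM to 400000 nM, and a fair chance that only a limit is reported.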

Compound 3, half-maximal cytotoxic concentration: >= 200000 nM
Compound 3 gave a limit, no number; the forecaster's own chance of this, stated with the estimate: 40%; the middle value lies on the limit itself.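

Trimming butyl to isopropyl on an amide-type nitrogen gives the first step that can be read at this position in this assay, namely an at least 1.1-fold higher number from compound 2 to compound 3 (0.05 log units; that floor lies within the scatter). From the compounds shown here alone, compound 3 carries a limit rather than a number, so this step is only a floor, and how far the true value lies beyond it remains unknown. Even so, the change to isopropyl gives no sign that the cells tolerate less compound than they do with butyl, and the measured set now gathers at the top of what this assay reports: the limit of >= 200000 nM in this assay, at which 2 of the 3 values shown sit.

With compound 2 still the only one holding a true number, the compounds shown leave open how much the group on this nitrogen can change the tolerated amount, if it changes it at all. A longer chain such as octyl, or a chain ending in an amine or a carboxylic acid, in place of butyl at this spot could show whether any group here gives a clear step away from compound 2 in this assay.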